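A few compounds are considered here, and "the series" means these few. Any claim that something is new, unique, unknown or untested is made for them only; others in the source may bear on it.

Compound 1 `CCC(C)CNc1cc(-c2[nH]c(SC)nc2-c2ccc(F)cc2)ccn1`: 2760 nM
Compound 2 `Fc1ccc(-c2nc(SCc3ccccc3)[nH]c2-c2ccnc(F)c2)cc1`: "not determined" (no result reported)

In a functional assay on blood (Homo sapiens) for inhibition (a higher number here means a weaker inhibitor, a lower number a stronger inhibitor), compound 1 gives 2760 nM. Within the data shown here, for compound 2 the entry in this assay reads "not determined" (no result reported), so compound 1 stands as the only measured value in this set, with nothing to rank it against. Compound 3 `CCC(Nc1cc(-c2[nH]c(SC)nc2-c2ccc(F)cc2)ccn1)c1ccccc1` is the next compound, and it differs from compound 1 by 1-phenylpropyl in place of 2-methylbutyl on a nitrogen on an aromatic ring. Among the measured compounds shown here, no measured pair covers a change of this kind, so the direction of the step is open; the expected step is small, a 1.4-fold lower number from compound 1 to compound 3 (0.14 log units; within the scatter), and not clearly beyond the scatter. Compound 3 is therefore estimated at 2000 nM, with a range from 500 nM to 8000 nM.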

Compound 3, half-maximal inhibitory concentration: 7640 nM
Beside the measured number, compound 3's estimate is 3.8-fold (0.58 log units) below it; the range from low to high includes it.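

Replacing 2-methylbutyl with 1-phenylpropyl on a nitrogen on an aromatic ring gives a 2.8-fold higher number from compound 1 to compound 3 (0.44 log units; beyond the scatter) in this assay. Among these compounds, this is the first sign that this position responds to a change, and here the group with the six-membered aromatic ring goes with the weaker inhibitor, though this rests on one pair. Nothing available bears on why the number rises. The compounds shown leave open whether the aromatic ring itself or the rest of the 1-phenylpropyl group carries the step. A benzyl group or a cyclohexyl ring at this nitrogen would bear on that question.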